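The compounds below may be only part of what the source reports. "The series", "measured", "known", "first", "only" and "open" are said of these compounds alone.

Three close relatives of one shared core have been measured in an assay on microsomes from intestine for inhibition of acyl-CoA:cholesterol acyltransferase (Oryctolagus cuniculus); a lower number here means a stronger inhibitor, a higher number a weaker inhibitor. Compound 1 `Cc1cc(C)c(NC(=O)N(Cc2ccc(-c3ccnn3C)cc2)C2CCCCCC2)c(C)c1` gives 24 nM. Compound 2 `Cc1cc(C)c(NC(=O)N(Cc2cccc(-c3ccnn3C)c2)C2CCCCCC2)c(C)c1` gives 35 nM in this assay; the difference between the cores of compound 1 and compound 2 is not broken down here. Compound 3 `Cc1cc(C)c(NC(=O)N(Cc2ccc(-c3cnn(C)c3)cc2)C2CCCCCC2)c(C)c1` gives 47 nM in this assay. Compound 3 differs from compound 1 by a single change, (1-methyl-1H-pyrazol-4-yl in place of 1-methyl-1H-pyrazol-5-yl on an aromatic carbon), and that change made a 2.0-fold higher number from compound 1 to compound 3 (0.29 log units; within the scatter), a small step.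

Compound 4 `Cc1cc(C)c(NC(=O)N(Cc2cccc(-c3cnn(C)c3)c2)C2CCCCCC2)c(C)c1` has not yet been measured. It differs from compound 2 by 1-methyl-1H-pyrazol-4-yl in place of 1-methyl-1H-pyrazol-5-yl on an aromatic carbon. Within the data shown here, this is the same kind of change as the one from compound 1 to compound 3, but not the same: there the place was para to a large group, here it is meta to a large group. A step of roughly the earlier size is expected for this change, a 1.7-fold higher number from compound 2 to compound 4 (0.23 log units; within the scatter). Starting from compound 2 with 35 nM, compound 4 is estimated at 60 nM in this assay, with a likely range from 30 nM to 130 nM, the wider range reflecting the different place of the change.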

Compound 4, half-maximal inhibitory concentration: 44 nM
Estimate against measurement, compound 4: 1.4-fold (0.13 log units) above, and the stated range covers the measured number.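

In this assay, putting 1-methyl-1H-pyrazol-4-yl in place of 1-methyl-1H-pyrazol-5-yl gave a 1.3-fold higher number from compound 2 to compound 4 (0.10 log units; within the scatter), so on this second core the change is again a small step. Set side by side, the two steps do not differ by more than repeated measurements would: the same change on two cores in this assay, a 2.0-fold higher number (0.29 log units; within the scatter) from compound 1 to compound 3 and a 1.3-fold higher number (0.10 log units; within the scatter) from compound 2 to compound 4, 1.6-fold (0.19 log units) apart, within the scatter of two such steps. The change therefore carried across these two cores without a step beyond the scatter, but this does not show that it has a real effect on the number in either core, and two cores cannot show how it would behave on others in the series.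

From the compounds shown here alone, all four compounds carry a 1-methylpyrazole, so it remains open what an ethyl group in place of the methyl, or an amine or a carboxylic acid in place of the whole pyrazole, would do to the number. Also open, going by these compounds, is whether changes elsewhere on the shared core would alter the small steps seen here.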